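The compounds below may be only part of what the source reports. "The series", "measured", "known", "first", "only" and "open" are said of these compounds alone.

Working notes on the series. The shared core of compound 1 `O=C1O[C@H]([C@@H](O)Cn2cc(-c3cccc(O)c3)nn2)C(OCc2ccccc2)=C1OCc1ccccc1` carries, on the triazole arm, a 3-hydroxyphenyl group; in a functional assay on SW-620 cells (Homo sapiens) for antiproliferative activity, read by MTT assay, with a stated time of 72 h (a lower number here means a stronger inhibitor, a higher number a weaker inhibitor), compound 1 gives > 100000 nM, which is a limit of the assay and not a number (the limit of > 100000 nM in this assay, at which 1 of the 3 values shown sits). Compound 2 `CCCCCc1ccc(-c2cn(C[C@H](O)[C@H]3OC(=O)C(OCc4ccccc4)=C3OCc3ccccc3)nn2)cc1` gives 12200 nM in this assay, and compound 3 `CCCCCCCCCCc1cn(C[C@H](O)[C@H]2OC(=O)C(OCc3ccccc3)=C2OCc2ccccc2)nn1` gives 45200 nM, the highest of the two numbers obtained; the step of a 3.7-fold higher number from compound 2 to compound 3 (0.57 log units; beyond the scatter) is modest. Against compound 1 the steps of an at least 8.1-fold lower number from compound 1 to compound 2 (0.91 log units; beyond the scatter) and an at least 2.2-fold lower number from compound 1 to compound 3 (0.34 log units; beyond the scatter) can only be read as lower bounds.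

Compound 4 `O=C1O[C@H]([C@@H](O)Cn2cc(CNS(=O)(=O)c3ccc(Cl)cc3)nn2)C(OCc2ccccc2)=C1OCc1ccccc1` is reached from compound 3 by the change (((4-chlorophenyl)sulfonyl)amino in place of nonyl on a saturated chain carbon bound to an aromatic carbon). The entering group brings one six-membered aromatic ring, one hydrogen-bond donor and two acceptors, where nonyl had none. Among the compounds with values here, no measured step covers a sulfonamide; the only ring-bearing comparison is the step from compound 2 to compound 3, and the only donor-bearing compound is compound 1, which sits at the limit. The expectation for compound 4 is therefore a step of a 1.3-fold lower number from compound 3 to compound 4 (0.11 log units; within the scatter), with wide uncertainty in either direction. Compound 4 is estimated at 35000 nM, within 8000 nM to 150000 nM, in this assay.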

Compound 4, half-maximal inhibitory concentration: 18000 nM
Beside the measured number, compound 4's estimate is 1.9-fold (0.29 log units) above it; measured number inside the range.
By their numbers in this assay, from the lowest: compounds 2 and 4 (each within the scatter of the next); then compound 3. At a limit, above all of these: compound 1.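

On the saturated chain carbon bound to an aromatic carbon, in this assay, ((4-chlorophenyl)sulfonyl)amino in place of nonyl gives a 2.5-fold lower number from compound 3 to compound 4 (0.40 log units; beyond the scatter), the first measured sign that a sulfonamide arm carrying an aromatic ring is compatible with a lower number than the plain alkyl arm. The comparison with the aryl arm gives a 1.5-fold higher number from compound 2 to compound 4 (0.17 log units; within the scatter), so the (((4-chlorophenyl)sulfonyl)amino)methyl and 4-pentylphenyl arms cannot be ordered, and an arm with a hydrogen-bond donor now has a number in this series, which compound 1 does not provide. The step of an at least 5.5-fold lower number from compound 1 to compound 4 (0.74 log units; beyond the scatter) can be read only as a lower bound, since compound 1 stands at a limit of the assay: the limit of > 100000 nM in this assay, at which 1 of the 4 values shown sits.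

The compounds shown leave open which part of the entering group goes with the step, the chlorine, the sulfonyl or the aromatic ring, and an unsubstituted benzenesulfonamide or a carboxamide on the same arm would begin to separate these. They also leave open how an amine or a carboxylic acid at the end of this arm would read in this assay.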